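Aryl swap on the shared core, compound 2 to compound 3

This account rests on a few compounds, and the source may have more. Where it says the series, first, only, none or still open, it means among the compounds named here.

Measured so far:
compound 1 `COc1cc(C(=O)c2cn(-c3ccccc3)cc2-c2ccc([N+](=O)[O-])cc2)cc(OC)c1OC` gives 590 nM
compound 2 `COc1ccc(Br)cc1-c1cn(-c2ccccc2)cc1C(=O)c1cc(OC)c(OC)c(OC)c1` gives 2200 nM

In a functional assay on MCF7 cells (Homo sapiens) for cytotoxicity, read by MTT assay, with a stated time of 96 h (on this read-out higher numbers stand for weaker inhibition and lower numbers for stronger inhibition), compound 2 gives 2200 nM and holds the higher of the two numbers. Compound 3 `COc1cc(C(=O)c2cn(-c3ccccc3)cc2-c2c(F)cc(F)cc2F)cc(OC)c1OC` follows from compound 2 through 2,4,6-trifluorophenyl in place of 5-bromo-2-methoxyphenyl on an aromatic carbon and carries 2,4,6-trifluorophenyl in place of 5-bromo-2-methoxyphenyl on an aromatic carbon. For the measured compounds named here, one measured step bears on this change, a 3.7-fold higher number from compound 1 to compound 2 (0.57 log units; beyond the scatter) and it is modest. Going by the values given here, with only that step to go on, a modest move towards lower numbers is expected. The expected step is a 2.0-fold lower number from compound 2 to compound 3 (0.30 log units; within the scatter) as an estimate. For compound 3 the estimated value is 1100 nM (expected range 300 nM to 3500 nM).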

Compound 3, half-maximal inhibitory concentration: 180 nM
Beside the measured number, compound 3's estimate is 6.1-fold (0.79 log units) above it, and the stated range ends above it.
By their numbers in this assay, from the lowest: compound 3; then compound 1; then compound 2.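

In this assay the 2,4,6-trifluorophenyl group on this aromatic carbon gives a 12-fold lower number from compound 2 to compound 3 (1.09 log units; beyond the scatter) and a 3.3-fold lower number from compound 1 to compound 3 (0.52 log units; beyond the scatter) and places compound 3 lowest of the three. The earlier pair showed only a rise with 5-bromo-2-methoxyphenyl; this position now also gives a number below both earlier compounds. Nothing at hand accounts for the size of these steps.

On these data alone, whether all three fluorines are needed, or one alone would give the same reading, stays open. As far as these compounds go, how an amine or a carboxylic acid on this aryl group would read is also open.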